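The source may report more compounds than this note shows. Statements on the series, on what has been measured and on what is new or still open speak of the compounds shown alone.

Measured compounds in the series:

compound 1 `CS(=O)(=O)/C(C#N)=C/c1c[nH]c2ccccc12` — in a functional assay on MT4 cells (Homo sapiens) for antiproliferative activity, read by MTT assay, with a stated time of 96 h (a lower number here means that less compound is needed, a higher number that more compound is needed for the effect), compound 1 gives > 100000 nM, a limit of the assay.
compound 2 `N#C/C(=C\c1c[nH]c2ccccc12)S(=O)(=O)c1ccccc1` — in this assay compound 2 gives > 100000 nM, again only a limit.
compound 3 `Cn1cc(/C=C(\C#N)S(=O)(=O)c2ccccc2)c2ccccc21` — in this assay compound 3 gives > 100000 nM, also a limit.

Compound 2 therefore stands at the limit, not at a number, and the two other values shown sit at the same limit (the limit of > 100000 nM in this assay, at which 3 of the 3 values shown sit). The step from compound 1 to compound 2, phenyl in place of methyl on a sulfonyl sulfur, is a step that the two limits leave unreadable from compound 1 to compound 2. The step from compound 2 to compound 3, methyl in place of hydrogen on an aromatic nitrogen, is a step that the two limits leave unreadable from compound 2 to compound 3. Among the compounds with values here, neither step gives a readable size, so there is no measured step that tells how a change on the core of compound 2 shifts this assay.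

Compound 4 `COc1ccc(-c2[nH]c3ccccc3c2/C=C(\C#N)S(=O)(=O)c2ccccc2)cc1` is to be measured. Its difference from compound 2 is 4-methoxyphenyl in place of hydrogen on an aromatic carbon. Since every value shown is a limit, no direction or size can be drawn from the measured steps for this change. The expectation for compound 4 in this assay is therefore placed near the limit, with the estimated step from compound 2 being an at least 1.2-fold lower number from compound 2 to compound 4 (0.09 log units; that floor lies within the scatter), carrying wide uncertainty. Compound 4 is estimated at 80000 nM, within a range from 15000 nM to 300000 nM.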

Compound 4, half-maximal effective concentration: 200 nM
For compound 4 the middle estimate is 400-fold (2.60 log units) above the measured one; measured number below the stated range.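

In this assay, within the data shown here, the aromatic carbon next to the ring nitrogen is the first place on the shared core where a change gives a readable result: 4-methoxyphenyl in place of hydrogen is an at least 500-fold lower number from compound 2 to compound 4 (2.69 log units; beyond the scatter). The size is a floor, not an exact figure, since compound 2 stands only at a limit, and compound 4 is the one compound shown with a real number. The changes on the sulfonyl sulfur and on the aromatic nitrogen cannot be read, so this carbon is the only position with a measured effect, while the rest of the series stays where it was: the limit of > 100000 nM in this assay, at which 3 of the 4 values shown sit.

The compounds shown do not separate the contribution of the phenyl ring from that of its methoxy group, and a plain phenyl, a methyl or a phenyl bearing an amine or a carboxylic acid on this same carbon would address that. Also open, going by these compounds, is whether, with 4-methoxyphenyl in place, methyl instead of phenyl on the sulfonyl sulfur or methyl instead of hydrogen on the aromatic nitrogen shifts the value of compound 4.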